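This account rests on a few compounds, and the source may have more. Where it says the series, first, only, none or still open, it means among the compounds named here.

Compound 1 `COc1ccc(C(=O)/C=C\Nc2ccc(-c3nc4cc(OC)c(OC)c(OC)c4s3)cc2)cc1[N+](=O)[O-]` belongs to a small set of enaminone-linked benzothiazoles tested in a functional assay on A549 cells (Homo sapiens) for antiproliferative activity, read by sulforhodamine B assay, with a stated time of 48 h; on this read-out lower numbers stand for stronger inhibition and higher numbers for weaker inhibition. In this assay compound 1 gives 21200 nM, the highest of the two numbers recorded. Compound 2 `COc1ccc2nc(-c3ccc(N/C=C\C(=O)c4ccc(OC)c(F)c4)cc3)sc2c1`, which carries a different substitution pattern on the shared core and a fluoro group in place of the nitro group, gives 900 nM; the two compounds differ in more than one place, so their values can only be set side by side, not read as a single step. Compound 3 `COc1ccc(C(=O)/C=C\Nc2ccc(-c3nc4cc(OC)c(OC)c(OC)c4s3)cc2)cc1F` keeps the core of compound 1 and changes only the terminal ring: fluoro in place of nitro on an aromatic carbon. For the measured compounds named here, no measured step of exactly this kind is available, so the expectation for compound 3 rests on the value of compound 2, whose fluoro-bearing ring gives 900 nM. Compound 3 is therefore expected to show a step of a 5.3-fold lower number from compound 1 to compound 3 (0.72 log units; beyond the scatter) toward stronger inhibition, beyond the scatter, with an estimated value of 4000 nM and a likely range from 1000 nM to 16000 nM.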

Compound 3, half-maximal inhibitory concentration: 15500 nM
The estimate for compound 3 lay 3.9-fold (0.59 log units) below the measured number; the measured number falls inside the stated range.
By their numbers in this assay, from the lowest: compound 2; then compounds 3 and 1 (each within the scatter of the next).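

In this assay, for the compounds shown here, fluoro in place of nitro on this aromatic carbon, ortho to a methoxy group, gives a 1.4-fold lower number from compound 1 to compound 3 (0.14 log units; within the scatter), the first comparison here that isolates a single change. On the core of compound 1, the 4-methoxy-3-nitrophenyl and 3-fluoro-4-methoxyphenyl rings are therefore not told apart by this read-out, even though the exchange replaces the three heavy atoms of nitro with the single atom of fluoro and removes the hydrogen-bond acceptors counted on nitro. No measured property of these groups is available to account for this result. The compounds shown leave open whether an amine or a carboxylic acid on this carbon would stand apart from nitro and fluoro. They also leave open whether the same match would hold with the substitution pattern of compound 2 on the shared core.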